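The compounds below may be only part of what the source reports. "The series", "measured", "known", "first", "only" and "open" are said of these compounds alone.

Measured so far:
- Compound 1, `Cc1cc(Cl)cc(C)c1OCC(C)O`: 3.52
- Compound 2, `OCC(O)COc1c(Cl)cccc1Cl`: 1.88
- Compound 3, `Cc1cc(Cl)ccc1OCC(C)O`: 2.84

Of the compounds shown here, three have been measured in a physicochemical assay for lipophilicity, measured as octanol-water partition (a lower number here means a more polar compound, a higher number a more lipophilic compound), and a fourth, compound 4 `Cc1cc(Cl)c(OCC(O)CO)c(Cl)c1`, has not. Compound 2 gives the lowest number of the three; its nearest neighbour is compound 3, and compound 1 lies furthest from it. The difference between the core of compound 2 and the core of compound 3 is not broken down here.

One change recurs twice among these compounds. From compound 3 to compound 1 the change is methyl in place of hydrogen on an aromatic carbon, and that step is measured: a number 0.68 log units higher from compound 3 to compound 1 (beyond the scatter). From compound 2 to compound 4 the change is methyl in place of hydrogen on an aromatic carbon. The two changes are the same kind of change, not the same: in compound 1 the entering methyl sits ortho to a group of 5 heavy atoms, meta to a chloro group and meta to a methyl group, whereas in compound 4 it sits meta to two chloro groups and para to a group of 6 heavy atoms.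

Because compound 3 to compound 1 gave a number 0.68 log units higher from compound 3 to compound 1 (beyond the scatter), the same kind of change is expected to raise the number in this assay by a comparable amount, estimated as a number 0.57 log units higher from compound 2 to compound 4 (beyond the scatter). On that basis compound 4 is expected to give about 2.45, most likely between 2.1 and 2.8.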

Compound 4, partition coefficient: 2.4
For compound 4 the middle estimate is 0.05 log units above the measured one; the measured number falls inside the stated range.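

In this assay the change of methyl in place of hydrogen on an aromatic carbon gives a number 0.52 log units higher from compound 2 to compound 4 (beyond the scatter) and so joins a number 0.68 log units higher from compound 3 to compound 1 (beyond the scatter) as a second upward step, both of them modest and beyond the scatter, which shows that in this series the direction of the step held when the change was carried from one core to another. Within the data shown here, this rests on only two pairs, and the entering methyl does not stand in the same place in both: in compound 4 it sits meta to two chloro groups and para to a group of 6 heavy atoms, while in compound 1 its surroundings differ, so the result does not show that the step would hold on other cores or at other places on the ring. No measurement at hand speaks to what lies behind either step.

The compounds shown leave open how the same change would behave on a core carrying an amine or a carboxylic acid. They also leave open whether an ethyl group or a longer chain entering at the same place would give a step of similar size.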